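Aryl amide exchange from compound 2 to compound 3

The source may report more compounds than this note shows. Statements on the series, on what has been measured and on what is new or still open speak of the compounds shown alone.

Measured so far:
compound 1 `Nc1cccc2c(-c3cccc(NC(=O)c4ccc5c(c4)OCCO5)c3)ccnc12`: 11400 nM
compound 2 `CC(=O)Nc1cccc2c(-c3cccc(NC(=O)c4ccc(Cl)c(C(F)(F)F)c4)c3)ccnc12`: 2700 nM

In a functional assay on UACC-257 cells (Homo sapiens) for antiproliferative activity, read by sulforhodamine B assay, with a stated time of 48 h (a lower number here means a stronger inhibitor, a higher number a weaker inhibitor), compound 2 gives 2700 nM, the lowest of the two numbers. Compound 1 gives 11400 nM, a higher number beyond the scatter, though compound 1 differs from compound 2 in two places. Compound 3 `CC(=O)Nc1cccc2c(-c3cccc(NC(=O)c4ccc5c(c4)OCCO5)c3)ccnc12` differs from compound 2 by 2,3-dihydro-1,4-benzodioxin-6-yl in place of 4-chloro-3-(trifluoromethyl)phenyl on a carbonyl carbon. For the measured compounds named here, no measured pair isolates this exchange. A step to a higher number is expected, a 2.6-fold higher number from compound 2 to compound 3 (0.41 log units; beyond the scatter), because compound 1, which carries the entering group, gives 11400 nM. Compound 3 is estimated at 7000 nM, with a range from 2500 nM to 20000 nM.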

Compound 3, half-maximal inhibitory concentration: > 20000 nM
Compound 3: no number, only a limit (the forecaster's own chance of this, stated with the estimate: 5%); middle value at least 2.8-fold (0.45 log units) from the limit.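

With the acetyl on the nitrogen held constant, 2,3-dihydro-1,4-benzodioxin-6-yl in place of 4-chloro-3-(trifluoromethyl)phenyl on a carbonyl carbon gives an at least 7.4-fold higher number from compound 2 to compound 3 (0.86 log units; beyond the scatter) in this assay, an isolated reading of this exchange. Compound 3 gives a limit of the assay and not a number: the limit of > 20000 nM in this assay, at which 1 of the 3 values shown sits.

Acetyl in place of hydrogen on a nitrogen on an aromatic ring gives an at least 1.7-fold higher number from compound 1 to compound 3 (0.24 log units; that floor lies within the scatter), so this pair shows no change at that nitrogen. Open, going by these compounds, is how an unsubstituted phenyl or a pyridine ring on the carbonyl carbon would read in this assay. Also open, on these data alone, is how 4-chloro-3-(trifluoromethyl)phenyl reads with hydrogen in place of acetyl.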